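The source may report more compounds than this note shows. Statements on the series, on what has been measured and on what is new or still open speak of the compounds shown alone.

Measured so far:
compound 1, `C=CC(=O)Oc1ccc(/C=C/C(=O)c2c(OC)cc3c(c2OC(=O)C=C)CCC(C)(C)O3)cc1`: 290 nM
compound 2, `COc1cc2c(c(OC(C)=O)c1C(=O)/C=C/c1ccc(OC(C)=O)cc1)CCC(C)(C)O2`: > 30000 nM

In an assay on HEK293T cells for inhibition of nuclear factor NF-kappa-B complex (Homo sapiens), read by a luciferase reporter (on this read-out lower numbers stand for stronger inhibition and higher numbers for weaker inhibition), compound 1 gives 290 nM. Compound 2 is reported only as > 30000 nM, which is a limit of the assay and not a number. That value sits at the limit of > 30000 nM in this assay, at which 1 of the 2 values shown sits. Within the data shown here, compound 2 thus stands at the weak end of the two values shown, while compound 1 sits well inside the measurable range; the two compounds differ in two places, so no single step connects them.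

Compound 3, `C=CC(=O)Oc1c2c(cc(OC)c1C(=O)/C=C/c1ccc(OC(C)=O)cc1)OC(C)(C)CC2`, is not yet measured. It differs from compound 2 in one place: vinyl in place of methyl on a carbonyl carbon. Among the measured compounds shown here, compound 1 carries vinylcarbonyl in place of both acetyl groups of compound 2, and compound 3 takes only one of those two exchanges.

The step from compound 2 to compound 3 is expected to move toward stronger inhibition by an at least 10-fold lower number from compound 2 to compound 3 (1.00 log units; beyond the scatter), beyond the usual scatter, because compound 1 with two such groups gives 290 nM. Compound 3 is therefore estimated at 3000 nM, with a range from 700 nM to 30000 nM, and a fair chance that only a limit is reported again.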

Compound 3, half-maximal inhibitory concentration: 1040 nM
Beside the measured number, compound 3's estimate is 2.9-fold (0.46 log units) above it, and the stated range covers the measured number.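

In this assay, exchanging just one of the two acetoxy groups of compound 2 for (vinylcarbonyl)oxy gives an at least 28-fold lower number from compound 2 to compound 3 (1.46 log units; beyond the scatter), so a change of methyl to vinyl on a single carbonyl carbon is enough to bring activity into the measurable range. The second such group still counts, though by less: going back from two vinyl groups to one gives a 3.6-fold higher number from compound 1 to compound 3 (0.55 log units; beyond the scatter), so the two exchanges are not interchangeable in size, and compound 1 owes its value to both. The size of the first step is only a bound, as the value for compound 2 is a limit and not a number: the limit of > 30000 nM in this assay, at which 1 of the 3 values shown sits.

The compounds shown leave open whether the exchange at the other acetoxy group, taken alone, would give a similar gain. They also cannot separate the double bond from the added carbon, which a propanoyl group, with a saturated ethyl in place of the vinyl, would do, and they say nothing about a longer chain such as butanoyl at this carbonyl carbon.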